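Dropping one trifluoromethyl from the strongest compound

The source may hold more compounds than are shown below. What is called first, only, known or untested is meant among the compounds shown, and "the series" means these compounds.

These three compounds share a core in which a urea links two aromatic rings. Compound 1 `O=C(Nc1cccc(-n2cc(-c3ccncc3)c(-c3cc(O)cc(Cl)c3)n2)c1)Nc1ccc(Cl)c(C(F)(F)F)c1` gives in a functional assay on U-251 cells (Homo sapiens) for inhibition, read by sulforhodamine B assay, with a stated time of 48 h, tested at 1 uM (on this read-out lower numbers stand for a stronger effect and higher numbers for a weaker effect at the one concentration tested), a value of 56%, and compound 2 `O=C(Nc1cccc(-n2cc(-c3ccncc3)c(-c3cc(O)cc(Cl)c3)n2)c1)Nc1ccc(Cl)c(Cl)c1` gives 74%. The step of a number 18 percentage points higher from compound 1 to compound 2 (beyond the scatter) shows that swapping the trifluoromethyl for a chloro weakened the effect. Compound 3 `COc1cc(Cl)cc(-c2nn(-c3cccc(NC(=O)Nc4cc(C(F)(F)F)cc(C(F)(F)F)c4)c3)cc2-c2ccncc2)c1` gives 11%, the lowest of the three numbers and therefore the strongest effect, well beyond the scatter from compound 1 and from compound 2.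

Compound 4 `COc1cc(Cl)cc(-c2nn(-c3cccc(NC(=O)Nc4cccc(C(F)(F)F)c4)c3)cc2-c2ccncc2)c1` differs from compound 3 by hydrogen in place of trifluoromethyl on an aromatic carbon. Within the data shown here, no measured pair tells what removing a trifluoromethyl outright does; the only step that touches that group, a number 18 percentage points higher from compound 1 to compound 2 (beyond the scatter), replaced it with chloro and cost a modest amount of effect. A change from trifluoromethyl to hydrogen is larger than that, so a somewhat larger loss is expected in this assay, with the direction toward weaker effect the more likely one. Compound 4 is therefore expected to give about 32%, between 12% and 60%, a step of a number 21 percentage points higher from compound 3 to compound 4 (beyond the scatter).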

Compound 4, a percentage reported as activity, at one concentration (the size of the read-out at that concentration, not a potency): 47%
Beside the measured number, compound 4's estimate is 15 percentage points below it; the measured number falls inside the stated range.
By their numbers in this assay, from the lowest: compound 3; then compounds 4 and 1 (each within the scatter of the next); then compound 2.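

Replacing the trifluoromethyl with hydrogen on this ring gives a number 36 percentage points higher from compound 3 to compound 4 (beyond the scatter) in this assay, so the effect at the one concentration tested depends heavily on this group. This is the first pair shown in which a trifluoromethyl is removed outright rather than exchanged for another group, and here it sits meta to a trifluoromethyl group that stays in place. Nothing measured here explains why this one group matters so much.

The compounds shown leave open whether another group at this place, such as a nitrile or an amine, would keep the effect seen with compound 3 or lose it as hydrogen does. They also leave open whether removing the same group would cost as much in compounds carrying the hydroxyl of compound 1 instead of the methoxy of compound 3.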